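Swapping chloro for methyl on the core of compound 1

This account rests on a few compounds, and the source may have more. Where it says the series, first, only, none or still open, it means among the compounds named here.

Three compounds sharing one core have been examined in an assay on HepG2 cells for inhibition of Proprotein convertase subtilisin/kexin type 9 (Homo sapiens), read by AlphaLISA, with a stated time of 48 h; on this read-out higher numbers stand for weaker inhibition and lower numbers for stronger inhibition. Compound 1 `Clc1cccc2c(Cc3cc4ccccc4[nH]3)c[nH]c12` gives 2800 nM there, the lowest of the two numbers reported, so on the present evidence it is the strongest inhibitor. Compound 2 `Clc1ccc2[nH]cc(Cc3cc4ccccc4[nH]3)c2c1` carries its chloro at a different place on the same core and gives 10000 nM in this assay, a higher number that lies beyond the usual scatter. Compound 3 `Brc1ccc2[nH]cc(Cc3cc4ccccc4[nH]3)c2c1` carries bromo at the place used in compound 2. In this assay compound 3 is reported as "not active" (no number reported), without a number. No two of these compounds differ in one place only, so no single step can be read from the measured set.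

Compound 4 `Cc1cccc2c(Cc3cc4ccccc4[nH]3)c[nH]c12` is not yet measured. It differs from compound 1 by methyl in place of chloro on an aromatic carbon. Nothing measured here tells how this exchange moves the number, and the group that enters matches the group that leaves in count of heavy atoms. The step from compound 1 to compound 4 is therefore expected to stay within the scatter, a 1.3-fold higher number from compound 1 to compound 4 (0.10 log units; within the scatter). Compound 4 is estimated at 3500 nM in this assay, within a range from 1200 nM to 10000 nM.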

Compound 4, half-maximal inhibitory concentration: 900 nM
For compound 4 the middle estimate is 3.9-fold (0.59 log units) above the measured one, and the stated range ends above it.
By their numbers in this assay, from the lowest: compound 4; then compound 1; then compound 2.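

In this assay, among these compounds, the exchange of chloro for methyl on an aromatic carbon gives a 3.1-fold lower number from compound 1 to compound 4 (0.49 log units; beyond the scatter) and is the only single change that can be read so far. It shows that this place on the shared core responds to the group it carries, even when the entering and leaving groups each have one heavy atom, and that chloro is not needed here for inhibition. No measurement available here explains this shift.

The compounds shown leave open how an amine, a carboxylic acid, a methoxy group or a longer chain such as ethyl would move the number at this place. They also leave open whether methyl in place of chloro would give a similar step at the place where compound 2 carries its chloro.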